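Swapping fluorine for chlorine at the end of a side chain

The source may report more compounds than this note shows. Statements on the series, on what has been measured and on what is new or still open speak of the compounds shown alone.

Compound 1 `COCCOCn1cc[n+](C)c1/C=N/O` gives -2.81 in a physicochemical assay for lipophilicity; on this read-out lower numbers stand for lower lipophilicity and higher numbers for higher lipophilicity.
Compound 2 `C[n+]1ccn(CCC#N)c1/C=N/O` gives -3.3 in this assay.
Compound 3 `C[n+]1ccn(CCOCCF)c1/C=N/O` gives -2.62 in this assay.

All three share the same charged core carrying an oxime and differ only in the chain on the ring nitrogen. Compound 3 has the highest of the three numbers, but its separation from compound 1, a number 0.19 log units higher from compound 1 to compound 3 (within the scatter), lies within the scatter, so these two cannot be told apart. Compound 2 sits clearly lower, as a number 0.68 log units higher from compound 2 to compound 3 (beyond the scatter) shows, and the step of a number 0.49 log units lower from compound 1 to compound 2 (beyond the scatter) also falls outside the scatter.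

Compound 4 `C[n+]1ccn(CCOCCCl)c1/C=N/O` differs from compound 3 by chloro in place of fluoro on a saturated chain carbon, two bonds along the chain from an oxygen on a saturated carbon. Among the measured compounds shown here, none of the measured steps exchanges one halogen for another; each replaces a whole chain or its end group, so none bears directly on this change. Those larger changes moved this assay by modest amounts at most, and the present change is smaller than any of them. A small upward step is therefore expected, around the edge of the scatter, a number 0.32 log units higher from compound 3 to compound 4 (beyond the scatter). For compound 4 the expected value in this assay is -2.3, with a range from -2.8 to -1.8.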

Compound 4, distribution coefficient: -2.32
Estimate against measurement, compound 4: 0.02 log units above; the measured number falls inside the stated range.
By their numbers in this assay, from the lowest: compound 2; then compounds 1, 3 and 4 (each within the scatter of the next, the first and the last beyond it).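

Among the compounds shown here, compound 4 gives the first direct reading of a fluoro-to-chloro exchange on a saturated chain carbon, two bonds along the chain from an oxygen on a saturated carbon. The step of a number 0.30 log units higher from compound 3 to compound 4 (within the scatter) stays inside the usual scatter of this assay, so this exchange on its own does not separate the two compounds. Even so, the chloro compound stands clearly apart from the methoxy-bearing chain, with a number 0.49 log units higher from compound 1 to compound 4 (beyond the scatter) lying beyond the scatter, whereas the fluoro compound could not be told apart from it, and the contrast with the nitrile chain also reaches its widest here, at a number 0.98 log units higher from compound 2 to compound 4 (beyond the scatter) on the same read-out.

From the compounds shown here alone, with only these two halogens compared, the chain end remains open to other groups, such as bromo, hydroxyl or an amine, and to a longer chain carrying the same chloro end. Nothing available gives a reason for any of these numbers.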